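A Larger Amide Substituent and Its Expected Lipophilicity

A few compounds are considered here, and "the series" means these few. Any claim that something is new, unique, unknown or untested is made for them only; others in the source may bear on it.

Of the compounds shown here, two sharing one core have been measured in a physicochemical assay for lipophilicity, at pH 7.4; a higher number here means a more lipophilic compound, a lower number a more polar compound. Compound 1 `CNC(=O)c1cc(C(=O)NC)c2c(c1)[C@H](c1ccccc1)CO2` gives 3.2, the lower of the two numbers. Compound 2 `CNC(=O)c1cc(C(=O)NC)c2c(c1)[C@H](c1ccccc1)[C@@H](CF)O2` gives 3.3, and the change between them, fluoromethyl in place of hydrogen on a saturated ring carbon, brings a number 0.10 log units higher from compound 1 to compound 2 (within the scatter).

The step to be followed leads from compound 1 to compound 3 `CNC(=O)c1cc(C(=O)N[C@H]2[C@@H]3C[C@@H](O)C[C@@H]32)cc2c1OC[C@H]2c1ccccc1`, which has not yet been measured in this assay. The change is a group of 7 heavy atoms (6 carbon, 1 oxygen; one three-membered non-aromatic ring of carbon only, one five-membered non-aromatic ring of carbon only) in place of one carbon atom, on an amide-type nitrogen.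

Among the measured compounds shown here, no measured step matches this kind of change: the only step known, from compound 1 to compound 2, concerns a fluoromethyl on a saturated ring carbon and lies within the scatter, so it gives no guide to what a seven-atom group entering on the amide-type nitrogen will do. The expectation therefore rests on the counted difference alone and carries a wide range. For compound 3 the number in this assay is estimated at 3.5, with a range from 3 to 4. This estimate means a step of a number 0.30 log units higher from compound 1 to compound 3 (within the scatter) is expected, a moderate rise rather than a large one.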

Compound 3, distribution coefficient: 2.9
Compound 3: middle estimate off by 0.60 log units, on the high side, outside the stated range (below it).
By their numbers in this assay, from the lowest: compounds 3, 1 and 2 (each within the scatter of the next, the first and the last beyond it).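

At this amide-type nitrogen, a methyl can give way to a much larger group, with 7 heavy atoms, two non-aromatic rings and 4 defined stereocentres, and this assay still shows only a number 0.30 log units lower from compound 1 to compound 3 (within the scatter). This is the first step shown at this nitrogen, and the first in which the entering group brings a hydrogen-bond donor and a hydrogen-bond acceptor, so the count of added heavy atoms alone proved a poor guide to the number for this particular group. No measurement is available to explain this result, and it cannot be said whether the oxygen, the rings or their spatial arrangement account for it.

From the compounds shown here alone, a single step at this position cannot separate those parts of the entering group, so it remains open what the same two rings would give with an amine or a methoxy group in place of the oxygen-bearing group, or with no oxygen at all. Also open, going by these compounds, is whether an ethyl or a longer chain on the same nitrogen, with no rings, would stay within the scatter of compound 1 in this assay.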